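The source may report more compounds than this note shows. Statements on the series, on what has been measured and on what is new or still open speak of the compounds shown alone.

Working notes on the series. In a functional assay on DU-145 cells (Homo sapiens) for cytotoxicity, read by CCK-8 assay and cell counting, with a stated time of 2 days (a lower number here means a stronger inhibitor, a higher number a weaker inhibitor), compound 1 `Oc1cccc(-c2cc(-c3ccc(Cl)cc3)nc(-c3cccs3)c2)c1` gives 11600 nM. In this assay compound 2 `Oc1cccc(-c2cc(-c3ccc(Cl)cc3)nc(-c3cccnc3)c2)c1` gives 26800 nM. The change pyridin-3-yl in place of thiophen-2-yl on an aromatic carbon produced a 2.3-fold higher number from compound 1 to compound 2 (0.36 log units; beyond the scatter). Compound 3 `Oc1ccc(-c2cc(-c3cccc(Cl)c3)nc(-c3cccs3)c2)cc1` has the same atoms as compound 1, joined differently; the difference between the two cores is not broken down here. In this assay compound 3 gives 5740 nM, the lowest number of the three measured.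

Compound 4 `Oc1ccc(-c2cc(-c3cccnc3)nc(-c3cccc(Cl)c3)c2)cc1` is not yet measured. It differs from compound 3 by pyridin-3-yl in place of thiophen-2-yl on an aromatic carbon, the same kind of change as from compound 1 to compound 2, though the surroundings differ: in compound 3 the site is meta to a 3-chlorophenyl group and meta to a 4-hydroxyphenyl group, whereas in compound 1 it is meta to a 3-hydroxyphenyl group and meta to a 4-chlorophenyl group. A similar step is expected, a 2.3-fold higher number from compound 3 to compound 4 (0.36 log units; beyond the scatter), resting on the measured 2.3-fold higher number from compound 1 to compound 2 (0.36 log units; beyond the scatter). Compound 4 is therefore estimated at 13000 nM, with a range from 6500 nM to 28000 nM.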

Compound 4, half-maximal inhibitory concentration: 22900 nM
Estimate against measurement, compound 4: 1.8-fold (0.25 log units) below; measured number inside the range.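

In this assay, pyridin-3-yl in place of thiophen-2-yl again goes with a higher number, here a 4.0-fold higher number from compound 3 to compound 4 (0.60 log units; beyond the scatter). The two steps run in the same direction and their sizes cannot be told apart: the same change on two cores in this assay, a 2.3-fold higher number (0.36 log units; beyond the scatter) from compound 1 to compound 2 and a 4.0-fold higher number (0.60 log units; beyond the scatter) from compound 3 to compound 4, 1.7-fold (0.24 log units) apart, within the scatter of two such steps. Within the data shown here, the change therefore carries across these two cores, but this rests on only two pairs and shows neither why the number rises nor whether the step would hold on any other core.

Still open, from the compounds shown here alone, is how an amine such as morpholine or a carboxylic acid would read at this site in place of either ring. Also open, going by these compounds, is what a methoxy group in place of the hydroxy group would do.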